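The source may hold more compounds than are shown below. What is called first, only, known or untested is meant among the compounds shown, and "the series" means these compounds.

Measured so far in a physicochemical assay for lipophilicity; on this read-out lower numbers stand for lower lipophilicity and higher numbers for higher lipophilicity:
- compound 1 `CCCC(=O)OCOC(=O)c1ccccc1OC(C)=O`: 2.5
- compound 2 `CC(=O)Oc1ccccc1C(=O)OCC(=O)N(C)CCO`: 0.06
- compound 3 `COC(=O)c1ccccc1OC(C)=O`: 1.46

Compound 2 gives the lowest of the three numbers in this assay. Compound 3 sits nearest, with a number 1.40 log units higher from compound 2 to compound 3 (beyond the scatter), and compound 1 furthest, with a number 2.44 log units lower from compound 1 to compound 2 (beyond the scatter) in the other direction. Compound 4 `CCOC(=O)CNC(=O)COC(=O)c1ccccc1OC(C)=O` is not yet measured. It differs from compound 2 in one place: ((ethoxycarbonyl)methyl)amino in place of (2-hydroxyethyl)(methyl)amino on a carbonyl carbon.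

For the measured compounds named here, no measured step touches the carbonyl carbon where this change sits; the three steps all concern the saturated chain carbon bound to an oxygen. They do show that the substituent on that chain carbon moves this read-out beyond the scatter in either direction, as a number 1.04 log units lower from compound 1 to compound 3 (beyond the scatter) and a number 1.40 log units higher from compound 2 to compound 3 (beyond the scatter) show, so the chain attached through the amide is not inert. The group leaving carries a hydroxyl, the group entering an ethyl ester, so a step upward from compound 2 beyond the scatter is expected, smaller than a number 1.40 log units higher from compound 2 to compound 3 (beyond the scatter). For compound 4 a value of 1 is estimated, within 0.4 to 1.6, an expected step of a number 0.94 log units higher from compound 2 to compound 4 (beyond the scatter).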

Compound 4, partition coefficient: 0.99
Compound 4: middle estimate off by 0.01 log units, on the high side, within the range that was stated.
By their numbers in this assay, from the lowest: compound 2; then compound 4; then compound 3; then compound 1.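

For the compounds shown here, the carbonyl carbon, which no earlier step touched, now proves to be a place where this assay responds to the amino group it carries: ((ethoxycarbonyl)methyl)amino in place of (2-hydroxyethyl)(methyl)amino gives a number 0.93 log units higher from compound 2 to compound 4 (beyond the scatter) in this series. The two groups differ in more than one feature, among them the hydroxyl that leaves and the ethyl ester that enters, so the step belongs to the swap as a whole and not to any single part of it. No evidence on the cause of this step is to hand.

Open, as far as these compounds go, is how much of the step follows the ethyl ester itself, which a carboxylic acid or a longer chain ester on the same amino group would address. Also open, from the compounds shown here alone, is how a plain primary amide or a basic amine on this carbonyl carbon would read out.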